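The source may hold more compounds than are shown below. What is called first, only, known or untested is meant among the compounds shown, and "the series" means these compounds.

Measured so far in an ADME assay on a cell-free system (plasma, Mus musculus); a lower number here means a smaller unbound share, a higher number a larger unbound share of the compound:
Compound 1 `CN(C)S(=O)(=O)c1ccc(F)c(C#Cc2cc(Cl)ccc2OCC(=O)O)c1` gives 0.029
Compound 2 `CCCS(=O)(=O)c1ccc(F)c(C#Cc2cc(Cl)ccc2OCC(=O)O)c1` gives 0.007
Compound 3 `Cc1ccc(S(=O)(=O)N(C)C(C)C)cc1C#Cc1cc(Cl)ccc1OCC(=O)O` gives 0.005

Compound 3 lies within the scatter of compound 2 and beyond the scatter under compound 1. Compound 4 `Cc1ccc(S(=O)(=O)NC(C)C)cc1C#Cc1cc(Cl)ccc1OCC(=O)O` differs from compound 3 by hydrogen in place of methyl on a sulfonamide nitrogen and so carries hydrogen in place of methyl on a sulfonamide nitrogen. Among the measured compounds shown here, no measured step makes this change, and no measured compound has hydrogen on that nitrogen. For the measured compounds named here, the only step, a 4.1-fold lower number from compound 1 to compound 2 (0.62 log units; beyond the scatter), removes the sulfonamide nitrogen altogether and so bears only loosely, showing that a change on the sulfonyl sulfur can pass the scatter. A small rise in this assay is therefore expected, though only tentatively, with the estimated step of a 1.6-fold higher number from compound 3 to compound 4 (0.20 log units; within the scatter) staying about within the scatter. Compound 4 is estimated at 0.008 with an expected range from 0.004 to 0.018.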

Compound 4, unbound fraction: 0.01
Beside the measured number, compound 4's estimate is 1.3-fold (0.10 log units) below it; low and high end bracket the measured number.
By their numbers in this assay, from the lowest: compounds 3, 2 and 4 (each within the scatter of the next); then compound 1.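

In this assay, among the compounds shown here, the only measured step on this sulfonamide nitrogen (a 2.0-fold higher number from compound 3 to compound 4 (0.30 log units; within the scatter)) stays within the scatter, so hydrogen in place of methyl there does not clearly separate the two compounds. The isopropyl group and the rest of the structure are shared, so this reading concerns that one change alone. Nothing available gives a cause for the result.

On these data alone, it remains open whether a longer chain or a cyclopropyl group in place of isopropyl on that nitrogen would pass the scatter. As far as these compounds go, whether the same change would read alike on the core of compound 1 also remains open.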